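A few compounds are considered here, and "the series" means these few. Any claim that something is new, unique, unknown or untested is made for them only; others in the source may bear on it.

Compound 1 `CN1CCC(c2cn(-c3ccc(F)cc3)c3ccc(-c4cnn(C)c4)cc23)CC1` is the reference point here. Going by the values given here, in an in vitro assay on BHK cells for displacement of a labelled ligand from Alpha-1A adrenergic receptor (Bos taurus), read by scintillation counting, with a stated time of 20 min (a lower number here means a stronger inhibitor, a higher number a weaker inhibitor), compound 1 gives 2.7 nM, the lowest of the two numbers measured so far. Among the compounds with values here, the only other measured compound is compound 2 `CN1CCC(c2cn(-c3ccncc3)c3ccc(-c4cnn(C)c4)cc23)CC1`, which in this assay gives 38 nM; the step of a 14-fold higher number from compound 1 to compound 2 (1.15 log units; beyond the scatter) comes from swapping the group on the ring nitrogen of the shared core.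

Compound 3 `CN1CCC(c2cn(-c3ccc(F)cc3)c3ccc(-c4cccnc4)cc23)CC1` has not yet been measured. It differs from compound 1 at another place: pyridin-3-yl in place of 1-methyl-1H-pyrazol-4-yl on an aromatic carbon. Within the data shown here, no measured step touches this position, so the one known step, from compound 1 to compound 2, concerns a different part of the molecule and only shows that a ring swap on this core can move the number by a large amount. For compound 3 a small shift is expected, and a step like a 1.9-fold higher number from compound 1 to compound 3 (0.27 log units; within the scatter) is estimated, since the incoming group keeps the same size and a single ring nitrogen for accepting a hydrogen bond. Compound 3 is therefore expected to give about 5 nM in this assay, with a likely range from 1.5 nM to 20 nM.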

Compound 3, inhibition constant: 2.3 nM
Compound 3: middle estimate off by 2.2-fold (0.34 log units), on the high side, and the stated range covers the measured number.
By their numbers in this assay, from the lowest: compounds 3 and 1 (each within the scatter of the next); then compound 2.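

In this assay, pyridin-3-yl in place of 1-methyl-1H-pyrazol-4-yl on an aromatic carbon gives a 1.2-fold lower number from compound 1 to compound 3 (0.07 log units; within the scatter) and so leaves compound 1 and compound 3 indistinguishable, whereas the swap on the ring nitrogen gave a 14-fold higher number from compound 1 to compound 2 (1.15 log units; beyond the scatter). The new pair shows that, with the 4-fluorophenyl group in place, a six-membered aromatic ring with 1 hetero atom and 1 hydrogen-bond acceptor can stand where a five-membered aromatic ring with 2 hetero atoms and 2 hydrogen-bond acceptors stood, with both groups having 6 heavy atoms, and the number stays within the scatter. No supporting measurement is available to explain this result.

The compounds shown leave open whether this position accepts a group that is not an aromatic ring, such as a primary amine, a carboxylic acid or a longer alkyl chain. Going by these compounds, it also remains open whether pyridin-3-yl at this position would give a similar number when the pyridin-4-yl group of compound 2 sits on the ring nitrogen.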